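Trimming a tert-butyl group to isopropyl

A few compounds are considered here, and "the series" means these few. Any claim that something is new, unique, unknown or untested is made for them only; others in the source may bear on it.

Among the compounds with values here, in an ADME assay on Caco-2 cells (Homo sapiens) for permeability (on this read-out higher numbers stand for higher permeability and lower numbers for lower permeability), compound 3 (`CC(C)(C)c1ccc(/C=C/C(=O)N[C@@H]2O[C@H](CO)[C@@H](O)[C@H](O)[C@H]2O)cc1`) gives 87.7 nm/s and so stands in the upper part of the three numbers known so far. Compound 1 (`CC(C)c1ccc(C[C@H](C)C(=O)N[C@@H]2O[C@H](CO)[C@@H](O)[C@H](O)[C@H]2O)cc1`) gives 98.7 nm/s within the scatter of that figure, while compound 2 (`COC(=O)c1ccc(/C=C/C(=O)N[C@@H]2O[C@H](CO)[C@@H](O)[C@H](O)[C@H]2O)cc1`) gives 26.3 nm/s as a clearly lower number. The next compound to be measured, compound 4 (`CC(C)c1ccc(/C=C/C(=O)N[C@@H]2O[C@H](CO)[C@@H](O)[C@H](O)[C@H]2O)cc1`), departs from compound 3 in one place. The change is hydrogen in place of methyl on a saturated chain carbon bound to an aromatic carbon and two saturated chain carbons and it reads as hydrogen in place of methyl on a saturated chain carbon bound to an aromatic carbon and two saturated chain carbons, or tert-butyl to isopropyl.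

Within the data shown here, no measured step makes this exchange. Among the measured compounds shown here, the one step available, a 3.3-fold higher number from compound 2 to compound 3 (0.52 log units; beyond the scatter) is modest and concerns a different swap, tert-butyl in place of methoxycarbonyl on an aromatic carbon. Compound 1 also carries isopropyl and gives 98.7 nm/s but differs from compound 4 elsewhere as well, so it offers only indirect support. No step beyond the scatter is therefore expected in this assay for this small change. The estimated step is a 1.0-fold lower number from compound 3 to compound 4 (0.01 log units; within the scatter) and no clear direction is expected. The estimate for compound 4 is 85 nm/s with an expected range from 50 nm/s to 140 nm/s in this measurement.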

Compound 4, apparent permeability in the Caco-2 assay: 98.5 nm/s
Estimate against measurement, compound 4: 1.2-fold (0.06 log units) below; measured number inside the range.
By their numbers in the Caco-2 assay, from the lowest: compound 2; then compounds 3, 4 and 1 (each within the scatter of the next).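

Within the data shown here, in the Caco-2 assay, compound 3 gives 87.7 nm/s and compound 4 gives 98.5 nm/s, and the first direct reading of hydrogen in place of methyl on this saturated chain carbon gives a 1.1-fold higher number from compound 3 to compound 4 (0.05 log units; within the scatter) and so does not tell tert-butyl and isopropyl apart at this place. In the Caco-2 assay, isopropyl also stands apart from methoxycarbonyl on the aromatic carbon, with a 3.7-fold higher number from compound 2 to compound 4 (0.57 log units; beyond the scatter) for that exchange, as tert-butyl does with a 3.3-fold higher number from compound 2 to compound 3 (0.52 log units; beyond the scatter) and so the separation from compound 2 does not depend on keeping the full tert-butyl group. In a physicochemical assay for lipophilicity, measured as octanol-water partition (on this read-out lower numbers stand for lower lipophilicity and higher numbers for higher lipophilicity), compound 3 gives 0.496 and compound 4 gives 0.296, and the same trimming gives a number 0.20 log units lower from compound 3 to compound 4 (within the scatter) and so this read-out does not separate the pair either, and nothing at hand gives a reason for these results.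

As far as these compounds go, how far the trimming can go remains open: ethyl or a lone methyl on the aromatic carbon, or an amine or a carboxylic acid there, could stay with compound 3 and compound 4 in the Caco-2 assay or fall toward compound 2. Whether tert-butyl and isopropyl also read alike on the core of compound 1 is open too.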